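Compound 2 to compound 3: longer chain, new amide

The source may hold more compounds than are shown below. What is called first, only, known or untested is meant among the compounds shown, and "the series" means these compounds.

Measured so far:
compound 1 `COc1ccc(-c2oc3c(OC)c(OC)cc(OCCCC(=O)NCc4ccccn4)c3c(=O)c2O)cc1`: > 40000 nM
compound 2 `COc1ccc(-c2oc3c(OC)c(OC)cc(OCCCCC(=O)NCc4ccccn4)c3c(=O)c2O)cc1`: > 40000 nM

In a functional assay on FaDu cells (Homo sapiens) for antiproliferative activity, read by sulforhodamine B assay, with a stated time of 48 h (a higher number here means a weaker inhibitor, a lower number a stronger inhibitor), compound 1 gives > 40000 nM, which is a limit and not a number. In this assay compound 2 gives > 40000 nM, also a limit, so its standing is known only as a limit. Going by the values given here, the whole series so far sits at the limit of > 40000 nM in this assay, at which 2 of the 2 values shown sit.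

Compound 3 `CCCCCN(C)C(=O)CCCCCOc1cc(OC)c(OC)c2oc(-c3ccc(OC)cc3)c(O)c(=O)c12` keeps the shared core and differs as follows: (methyl(pentyl)carbamoyl)methyl in place of ((pyridin-2-yl)methyl)carbamoyl on a saturated chain carbon, four bonds along the chain from an oxygen on an aromatic ring. In words, (methyl(pentyl)carbamoyl)methyl stands in place of ((pyridin-2-yl)methyl)carbamoyl on a saturated chain carbon, four bonds along the chain from an oxygen on an aromatic ring.

Among the compounds with values here, the only measured step that bears on this is a step that the two limits leave unreadable from compound 1 to compound 2. Within the data shown here, it also alters the chain, but it offers no size and no direction, and no measured step covers the change of amide. Among the measured compounds shown here, no firm step is therefore expected in this assay, and a result close to the limit, or another limit, seems most likely. The expected change is an at least 1.3-fold lower number from compound 2 to compound 3 (0.12 log units; that floor lies within the scatter). Compound 3 is estimated at 30000 nM, with an expected range of 10000 nM to 60000 nM.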

Compound 3, half-maximal inhibitory concentration: > 40000 nM
Compound 3: a limit, no number; the forecaster's own chance of this, stated with the estimate: 60%; at least 1.3-fold (0.12 log units) between middle value and limit.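

In this assay, going by these compounds alone, compound 3 gives > 40000 nM, a limit and not a number, so no step from compound 1 or compound 2 to compound 3 can be read. The compounds shown leave open how far any of them differs from the others, and whether any chain length or amide on the shared core gives a measurable number: the limit of > 40000 nM in this assay, at which 3 of the 3 values shown sit.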